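Lengthening the ether on the hydroxyproline-derived core

The source may report more compounds than this note shows. Statements on the series, on what has been measured and on what is new or still open speak of the compounds shown alone.

compound 1: `Cc1cc(C(=O)N2CCCCc3ccccc32)ccc1CNC(=O)N1C[C@H](O)C[C@H]1C(=O)N(C)C` — 68%
compound 2: `CO[C@@H]1C[C@@H](C(=O)N(C)C)N(C(=O)NCc2ccc(C(=O)N3CCCCc4ccccc43)cc2C)C1` — 84%

In a functional assay on the whole organism (urine, strain Long-Evans) for inhibition, with Rattus norvegicus as the target, with a stated time of 1 h, at a dose of 1 mg/kg by the oral route (on this read-out higher numbers stand for more inhibition at the one dose given (going by the name of the read-out) and lower numbers for less inhibition), compound 1 gives 68%. Within the data shown here, compound 2 gives 84% in this assay and so stands as the higher of the two numbers measured, with compound 1 as its only neighbour. Among the measured compounds shown here, the one measured step, a number 16 percentage points higher from compound 1 to compound 2 (beyond the scatter), came from methyl in place of hydrogen on an oxygen on a saturated carbon.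

Compound 3 is `CCO[C@@H]1C[C@@H](C(=O)N(C)C)N(C(=O)NCc2ccc(C(=O)N3CCCCc4ccccc43)cc2C)C1`. It differs from compound 2 in one place: methyl in place of hydrogen on a saturated chain carbon bound to an oxygen on a saturated carbon. For the measured compounds named here, no measured pair shows exactly this change. Going by the values given here, the only step that bears on it is the one from compound 1 to compound 2, which grew the same ether by the same count of one carbon and gave a modest rise beyond the scatter. A second carbon added at the same place is expected to move the number little, so the step of a number 2 percentage points lower from compound 2 to compound 3 (within the scatter) is estimated to lie within the usual scatter, with no clear direction. For compound 3 the expected reading in this assay is 82%, with a range from 66% to 95%.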

Compound 3, a percentage reported as inhibition, in the whole organism at one dose (the size of the read-out at that dose, not a potency): 60%
Compound 3: middle estimate off by 22 percentage points, on the high side, and the stated range ends above it.
By their numbers in this assay, from the lowest: compounds 3 and 1 (each within the scatter of the next); then compound 2.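

Within this assay the second carbon on this ether does not repeat the effect of the first, since the change from methoxy to ethoxy gives a number 24 percentage points lower from compound 2 to compound 3 (beyond the scatter) and so reverses the direction seen when methyl first replaced the hydrogen on the oxygen, which gave a number 16 percentage points higher from compound 1 to compound 2 (beyond the scatter) in the earlier step. Ethyl in place of that same hydrogen gives a number 8 percentage points lower from compound 1 to compound 3 (within the scatter) and thus leaves no separation between the ethyl ether and the free hydroxyl, so among these three groups only the methoxy of compound 2 stands apart from the others. This position therefore answers to a single added methyl on a saturated chain carbon bound to an oxygen on a saturated carbon, and the response to chain length is not a steady trend across the three compounds. Nothing measured here accounts for the fall from methoxy to ethoxy.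

Still open, going by these compounds, is whether a longer chain such as propyl, a branched group such as isopropyl, or an ethyl chain ending in an amine would read like the methoxy or like the ethoxy. Also open, on these data alone, is whether the same order would hold at another oral dose or another stated time, as each reading here comes from one dose and is not a potency.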